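The compounds below may be only part of what the source reports. "The series", "measured", "known", "first", "only" and "open" are said of these compounds alone.

In a functional assay on HL-60 cells (Homo sapiens) for antiproliferative activity, read by MTT assay, with a stated time of 72 h (a higher number here means a weaker inhibitor, a lower number a stronger inhibitor), the two measured compounds give the following numbers:

- compound 1 `COc1ccc(OC)c(S(=O)(=O)N(C)c2ccc3[nH]c(-c4n[nH]c5ccccc45)cc3n2)c1`: 840 nM
- compound 2 `COc1ccc(S(=O)(=O)N(C)c2ccc3[nH]c(-c4n[nH]c5ccccc45)cc3n2)c(OC)c1`: 5180 nM

Compound 2 has the higher of the two numbers, and by a margin beyond the usual scatter, so it is the weaker inhibitor of the pair. Among the compounds with values here, the only measured step, a 6.2-fold higher number from compound 1 to compound 2 (0.79 log units; beyond the scatter), changes nothing but the group attached to the sulfonyl sulfur, and that alone moved the number by a modest but clear amount. Compound 3 `CN(c1ccc2[nH]c(-c3n[nH]c4ccccc34)cc2n1)S(=O)(=O)c1ccc(OC(F)(F)F)cc1` changes the same place again: 4-(trifluoromethoxy)phenyl in place of 2,4-dimethoxyphenyl on a sulfonyl sulfur. Compound 1 and compound 2 together show that this group matters, but with a single step, and one that does not involve a trifluoromethoxy group, nothing indicates which direction the new change takes or how far it goes. The expectation for compound 3 is therefore a number not far from compound 2, with a wide range on both sides. Compound 3 is estimated at 2500 nM, with a range from 600 nM to 10000 nM. The expected step of a 2.1-fold lower number from compound 2 to compound 3 (0.32 log units; beyond the scatter) is small against the width of that range.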

Compound 3, half-maximal inhibitory concentration: 1170 nM
For compound 3 the middle estimate is 2.1-fold (0.33 log units) above the measured one; the range from low to high includes it.
By their numbers in this assay, from the lowest: compounds 1 and 3 (each within the scatter of the next); then compound 2.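

In this assay, the change to 4-(trifluoromethoxy)phenyl on the sulfonyl sulfur gives a 4.4-fold lower number from compound 2 to compound 3 (0.65 log units; beyond the scatter), so the weaker result seen with 2,4-dimethoxyphenyl is not shared by every group that differs from 2,5-dimethoxyphenyl at this place. Set against 2,5-dimethoxyphenyl, the same group gives a 1.4-fold higher number from compound 1 to compound 3 (0.14 log units; within the scatter), which means that two differently built groups, one carrying two methoxy groups and the other a single trifluoromethoxy group, cannot be told apart here, and a dimethoxyphenyl group is not required for a number in this range. Nothing available explains why the numbers of these three compounds fall as they do.

The compounds shown leave open which part of the group on the sulfonyl sulfur governs the number, and a plain unsubstituted phenyl or a phenyl with a single methoxy group would help to separate these possibilities. They also leave open whether a phenyl carrying an amine or a carboxylic acid, or a simple butyl chain in place of the phenyl ring, would stay in this range.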